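The Same Amide Exchange Tried on a Second Core

This account rests on a few compounds, and the source may have more. Where it says the series, first, only, none or still open, it means among the compounds named here.

Of the compounds shown here, three have so far been measured in a functional assay (trachea) for antagonist activity, with Cavia porcellus as the target; on this read-out higher numbers stand for higher potency (the scale is a negative logarithm) and lower numbers for lower potency. Compound 1 `COC(=O)C(C(=O)c1ccc(Cn2ccc3ccc(NC(=O)CC4CCCC4)cc32)c(OC)c1)S(=O)(=O)c1ccccc1` gives 10.1 in this assay, and compound 3 `COc1cc(C(=O)NS(=O)(=O)c2ccccc2C)ccc1Cn1ccc2ccc(NC(=O)CC3CCCC3)cc21` gives 9.9 in this assay, the two numbers lying within the usual scatter of each other. The difference between the cores of compound 1 and compound 3 is not broken down here. Compound 2 `CCCCC(CC)C(=O)Nc1ccc2ccn(Cc3ccc(C(=O)NS(=O)(=O)c4ccccc4C)cc3OC)c2c1` gives 8.9 in this assay. It shares its core with compound 3 and differs from it only by 1-ethylpentyl in place of cyclopentylmethyl on a carbonyl carbon; that exchange produced a number 1.00 log units lower from compound 3 to compound 2 (beyond the scatter).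

Compound 4 `CCCCC(CC)C(=O)Nc1ccc2ccn(Cc3ccc(C(=O)C(C(=O)OC)S(=O)(=O)c4ccccc4)cc3OC)c2c1` remains to be measured in this assay. It stands to compound 1 as compound 2 stands to compound 3: the difference is 1-ethylpentyl in place of cyclopentylmethyl on a carbonyl carbon, and the place lines of the two exchanges read word for word alike, so it is the same change, now made on the core of compound 1. For the measured compounds named here, since the only measured instance of this change, from compound 3 to compound 2, gave a number 1.00 log units lower from compound 3 to compound 2 (beyond the scatter), a step of comparable size is expected here, and the estimate for the pair is a number 1.00 log units lower from compound 1 to compound 4 (beyond the scatter). That expectation rests on a single measured pair, so its uncertainty is wider than the scatter alone would suggest. On this basis compound 4 is expected to give 9.1 in this assay, with a likely range from 8.5 to 9.7.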

Compound 4, negative logarithm of the antagonist equilibrium constant: 8.5
Estimate against measurement, compound 4: 0.60 log units above; measured number inside the range.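

In this assay, the exchange of cyclopentylmethyl for 1-ethylpentyl on a carbonyl carbon gave a number 1.60 log units lower from compound 1 to compound 4 (beyond the scatter), so on the core of compound 1 the change lowered the number, as it had on the core of compound 3. The direction of the change therefore carried from one core to the other, but its size did not carry over unaltered, and the core on which it is made matters for how much is lost: the same change on two cores in this assay, a number 1.00 log units lower (beyond the scatter) from compound 3 to compound 2 and a number 1.60 log units lower (beyond the scatter) from compound 1 to compound 4, 0.60 log units apart, beyond the scatter of two such steps These two pairs are the only instances of the change in the compounds shown, so they do not explain why the size differs, and they cannot tell whether a further core would follow the smaller step, the larger one or neither.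

Among the compounds shown, the carbonyl carbon carries only cyclopentylmethyl or 1-ethylpentyl, so it remains open how an unbranched longer chain, a cyclohexyl ring or a chain ending in an amine would behave there on either core. Going by these compounds, it also remains open whether a carboxylic acid in place of the groups that differ between the two cores would keep the numbers of the cyclopentylmethyl compounds, or would alter the size of the step seen with 1-ethylpentyl.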